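What Losing a Methyl Might Do to Compound 1

The compounds below may be only part of what the source reports. "The series", "measured", "known", "first", "only" and "open" are said of these compounds alone.

In a functional assay on OVCAR-3 cells (Homo sapiens) (a higher number here means a weaker inhibitor of growth, a lower number a stronger inhibitor of growth), compound 1 `Cc1cc(C)c2c(O)cc(-c3ccc(Cl)cc3)nc2n1` gives 18200 nM and compound 2 `COc1ccc(-c2cc(O)c3c(C)cc(C)nc3n2)cc1` gives 32400 nM. For the measured compounds named here, these are the only two measurements so far. Going by the values given here, the comparison between them is a 1.8-fold higher number from compound 1 to compound 2 (0.25 log units; within the scatter), so the numbers do not separate compound 1 from its only measured neighbour.

Compound 3 `Cc1ccnc2nc(-c3ccc(Cl)cc3)cc(O)c12` has not yet been measured. It keeps the core of compound 1 and differs in one place: hydrogen in place of methyl on an aromatic carbon. This is hydrogen in place of methyl on an aromatic carbon, next to the ring nitrogen.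

Among the compounds with values here, no measurement so far tests this methyl. Within the data shown here, the one measured step, methoxy in place of chloro, is a different change at a different place, and it offers only indirect guidance: a 1.8-fold higher number from compound 1 to compound 2 (0.25 log units; within the scatter). A step beyond the scatter is therefore not expected in this assay, although the evidence is thin and the range must stay wide.

The estimated step is a 1.2-fold higher number from compound 1 to compound 3 (0.08 log units; within the scatter). For compound 3 the expected value is 22000 nM, with an estimated range from 8000 nM to 60000 nM.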

Compound 3, concentration for 50% growth inhibition: 3160 nM
For compound 3 the middle estimate is 7.0-fold (0.84 log units) above the measured one; measured number outside the range, below it.
By their numbers in this assay, from the lowest: compound 3; then compounds 1 and 2 (each within the scatter of the next).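

In this assay the change from methyl to hydrogen gives a 5.8-fold lower number from compound 1 to compound 3 (0.76 log units; beyond the scatter) and is the first step among these compounds to lie beyond the scatter. For the compounds shown here, the earlier step, methoxy in place of chloro, stayed within the scatter, so this result is the first sign that a single change can clearly shift the number on this core, and here the methyl next to the ring nitrogen is what changes. With the methyl gone, the compound is a stronger inhibitor of growth, but this rests on one pair of compounds, and nothing measured here indicates why the number falls.

Going by these compounds, it remains open whether only the loss of the methyl matters, or whether another group at this place, such as an ethyl chain, a fluorine atom or an amine, would give a similar or a larger step. On these data alone, it is also open whether the same change would give a step of similar size with methoxy in place of chloro, and what removing the remaining methyl would do.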